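From 4-methoxyphenyl to 2-fluorophenyl on a shared core

The source may hold more compounds than are shown below. What is called first, only, known or untested is meant among the compounds shown, and "the series" means these compounds.

Measured in a functional assay on MCF7 cells (Homo sapiens) for cytotoxicity, read by MTT assay, with a stated time of 48 h; a higher number here means a weaker inhibitor, a lower number a stronger inhibitor
- compound 1 `Cc1ccccc1-c1nnc(SCCn2c([N+](=O)[O-])cnc2C)o1` gives 15800 nM
- compound 2 `COc1ccc(-c2nnc(SCCn3c([N+](=O)[O-])cnc3C)o2)cc1` gives 10600 nM
- compound 3 `Cc1ncc([N+](=O)[O-])n1CCSc1nnc(-c2ccc([N+](=O)[O-])cc2)o1` gives 12700 nM

Compound 2 cannot be told apart from the other two measured compounds on these numbers. One measured step is a 1.5-fold lower number from compound 1 to compound 2 (0.17 log units; within the scatter) and the other is a 1.2-fold higher number from compound 2 to compound 3 (0.08 log units; within the scatter) and neither leaves the scatter.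

Compound 4 `Cc1ncc([N+](=O)[O-])n1CCSc1nnc(-c2ccccc2F)o1` departs from compound 2 in one place: 2-fluorophenyl in place of 4-methoxyphenyl on an aromatic carbon with 2-fluorophenyl in place of 4-methoxyphenyl on an aromatic carbon of a five-membered aromatic ring with 2 nitrogen and 1 oxygen. Within the data shown here, no measured compound carries 2-fluorophenyl, so the evidence is indirect. Among the measured compounds shown here, the closest precedent is a 1.5-fold lower number from compound 1 to compound 2 (0.17 log units; within the scatter) where 4-methoxyphenyl takes the place of 2-methylphenyl. The other is a 1.2-fold higher number from compound 2 to compound 3 (0.08 log units; within the scatter) where nitro takes the place of methoxy. Both changes on the aromatic part stayed within the scatter, and so the same is expected here, with no favoured direction. The expected step is a 1.2-fold higher number from compound 2 to compound 4 (0.07 log units; within the scatter) and nothing beyond the scatter is expected. For compound 4 the expected value is 12500 nM with a range from 6500 nM to 24000 nM in this assay as estimated here.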

Compound 4, half-maximal inhibitory concentration: 20500 nM
Compound 4: the middle estimate sits 1.6-fold (0.21 log units) below what was measured; the range from low to high includes it.
By their numbers in this assay, from the lowest: compounds 2, 3, 1 and 4 (each within the scatter of the next).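

In this assay, the change to 2-fluorophenyl gives a 1.9-fold higher number from compound 2 to compound 4 (0.29 log units; within the scatter), so this aromatic carbon of the shared core tolerates an exchange that removes the methoxy oxygen, with its 1 hydrogen-bond acceptor, and brings in fluorine without the number leaving the scatter. The second step, a 1.3-fold higher number from compound 1 to compound 4 (0.11 log units; within the scatter), adds the one direct comparison of two small groups on the same phenyl ring, fluoro in place of methyl, and it too stays within the scatter, so no listed step among these aryl groups separates one from another. No measurement shown bears on why these exchanges leave the cytotoxicity number within the scatter.

Whether an amine or a carboxylic acid on the phenyl ring would move the number beyond the scatter remains open, since every group shown at this position is a substituted phenyl. Also unresolved is what a longer chain between the sulfur and the rest of the shared core would do, as all four compounds carry the same link and are compared only in this assay.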